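The compounds below may be only part of what the source reports. "The series", "measured", "known", "first", "only" and "open" are said of these compounds alone.

Of the compounds shown here, three have so far been measured in an assay for inhibition of histone acetyltransferase KAT2B (Homo sapiens), read by TR-FRET, with a stated time of 10 min, tested at 50 uM; on this read-out higher numbers stand for more inhibition at the one concentration tested (going by the name of the read-out) and lower numbers for less inhibition. Compound 1 `CCOc1ccccc1/C=C1\SC(=S)N(CCCCCC(=O)OC)C1=O` gives 9%, compound 2 `Cc1cccc(NC(=O)CN2C(=O)/C(=C3\SC(=S)N(CCS(=O)(=O)O)C3=O)c3ccccc32)c1` gives 6%, and compound 3 `COc1ccc(/C=C2\SC(=S)N(CCCCCC(=O)O)C2=O)cc1Br` gives 8%. The three numbers sit within the scatter of one another, so compound 2 does not stand apart from the other two; all three show little inhibition at the single concentration tested. Compound 4 `O=C1Nc2ccccc2/C1=C1/SC(=S)N(CCS(=O)(=O)O)C1=O` has not yet been measured. It differs from compound 2 in one place: hydrogen in place of ((3-methylphenyl)carbamoyl)methyl on an amide-type nitrogen in a ring. Among the compounds with values here, no step between two measured compounds of this kind is known, so the change carries no record of its own. Because compound 2 gives 6%, compound 4 is expected to read about 6%, within -4% to 16%. The expected step of no change at the digits printed from compound 2 to compound 4 (within the scatter) is none beyond the scatter.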

Compound 4, a percentage reported as inhibition, at one concentration (the size of the read-out at that concentration, not a potency): < 5%
Compound 4 gave a limit, no number; the forecaster's own chance of this, stated with the estimate: 0%; middle value at least 1 percentage points from the limit.
By their numbers in this assay, from the lowest: compounds 2, 3 and 1 (each within the scatter of the next). At a limit, below all of these: compound 4.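

Replacing ((3-methylphenyl)carbamoyl)methyl with hydrogen on the amide-type nitrogen in a ring gives a number at least 1 percentage points lower from compound 2 to compound 4 (that floor lies within the scatter). Compound 4 carries a limit of the assay, not a number: the limit of < 5% in this assay, at which 1 of the 4 values shown sits. Within the data shown here, this is the first reading at this position, and it shows that removing the whole group brings no gain in inhibition and no loss that stands clear of the scatter.

On these data alone, it remains open whether a different group on this nitrogen, such as a methyl or a chain ending in an amine, would raise inhibition.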